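The source may report more compounds than this note shows. Statements on the series, on what has been measured and on what is new or still open speak of the compounds shown alone.

Measured so far:
- compound 1 `COc1ccc(-c2cccc(=O)n2-c2cc(OC)c(OC)c(OC)c2)cc1` gives < 10 nM (a limit)
- compound 2 `COc1ccc(-n2c(-c3cc(OC)c(OC)c(OC)c3)cccc2=O)cc1O` gives 1220 nM

Within the data shown here, in a functional assay on SK-OV-3 cells (Homo sapiens) for cytotoxicity, read by spectrophotometry, with a stated time of 72 h (on this read-out lower numbers stand for stronger inhibition and higher numbers for weaker inhibition), compound 2 gives 1220 nM as the only actual number so far. Compound 1 is recorded in this assay only as a limit of < 10 nM and not as a number.

Compound 3 `COc1cc(-c2cccc(=O)n2-c2ccc(F)cc2)cc(OC)c1OC` has 4-fluorophenyl in place of 3-hydroxy-4-methoxyphenyl on an aromatic nitrogen and otherwise matches compound 2. Among the measured compounds shown here, no measured step covers this change, so the expectation rests on compound 2 at 1220 nM alone. A move towards weaker inhibition in this assay, moderately beyond the scatter, is expected. The estimated change is a 2.9-fold higher number from compound 2 to compound 3 (0.46 log units; beyond the scatter) on this reasoning. For compound 3 the estimated value is 3500 nM with an expected range of 700 nM to 18000 nM overall.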

Compound 3, half-maximal inhibitory concentration: 9740 nM
Compound 3: the middle estimate sits 2.8-fold (0.44 log units) below what was measured, and the stated range covers the measured number.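

Among these compounds, on the aromatic nitrogen of the shared core, 4-fluorophenyl in place of 3-hydroxy-4-methoxyphenyl gives the first readable step in this assay: an 8.0-fold higher number from compound 2 to compound 3 (0.90 log units; beyond the scatter). This position therefore responds to the change, and of the two groups, 3-hydroxy-4-methoxyphenyl gives the lower number, though this rests on a single pair. Compound 1 differs from both other compounds in more than one place and stands as a limit rather than a number: the limit of < 10 nM in this assay, at which 1 of the 3 values shown sits.

As far as these compounds go, it remains open how much of the step belongs to the hydroxy, the methoxy or the fluorine, as the change swaps all of them at once. From the compounds shown here alone, it is also open how a phenyl ring carrying an amine or a carboxylic acid would read at this position in this assay.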